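This account rests on a few compounds, and the source may have more. Where it says the series, first, only, none or still open, it means among the compounds named here.

Compounds measured so far:
- compound 1 `C/C=C(\C)C(=O)O[C@H]1C[C@@]2(C)O[C@H]2[C@@H](OC(C)=O)[C@@]2(C)CC[C@@](O)(C(C)C)[C@H]12` — in a functional assay on Jurkat cells (Homo sapiens) for cytotoxicity, read by MTT assay, with a stated time of 72 h (on this read-out lower numbers stand for stronger inhibition and higher numbers for weaker inhibition), compound 1 reaches only the assay limit, > 100000 nM.
- compound 2 `CC1=CC[C@]2(C)[C@@H]([C@@H](OC(=O)c3ccc(O)cc3)C1)[C@](O)(C(C)C)C[C@@H]2O` — in this assay compound 2 gives 40300 nM.
- compound 3 `COc1ccc(C(=O)O[C@H]2CC(C)=CC[C@@]3(C)CC[C@@](O)(C(C)C)[C@H]23)cc1` — in this assay compound 3 gives 30500 nM.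

Among the two numbers that are not limits, compound 3 holds the lower one, yet its nearest neighbour, compound 2, sits within the usual scatter of it, so the two cannot be told apart. Compound 1 is known only as a limit in this assay (the limit of > 100000 nM in this assay, at which 1 of the 3 values shown sits).

Compound 4 `CC1=CC[C@@]2(C)CC[C@@](O)(C(C)C)[C@@H]2[C@@H](OC(=O)c2ccc(O)cc2)C1` differs from compound 3 in one place: hydrogen in place of methyl on an oxygen on an aromatic ring. Within the data shown here, since no step between measured compounds is available, the expectation rests on the two numbers alone. Compound 2, which also carries a 4-hydroxyphenyl ester, gives 40300 nM, a value within the scatter of compound 3. The step from compound 3 to compound 4 is therefore expected to stay within the scatter, without a clear direction, a 1.1-fold higher number from compound 3 to compound 4 (0.06 log units; within the scatter). Compound 4 is estimated at 35000 nM, with a range from 12000 nM to 100000 nM.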

Compound 4, half-maximal inhibitory concentration: > 100000 nM
Compound 4: a limit, no number; the forecaster's own chance of this, stated with the estimate: 15%; middle value at least 2.8-fold (0.45 log units) away from the limit.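

Read in this assay, the place on the aromatic ring is not indifferent to this change: going from methoxy to hydroxy gives an at least 3.2-fold higher number from compound 3 to compound 4 (0.51 log units; beyond the scatter), a step beyond the scatter that the earlier compounds could not show. The 4-hydroxyphenyl ester is also sensitive to a second place, the saturated ring carbon, where hydrogen in place of hydroxy gives an at least 2.4-fold higher number from compound 2 to compound 4 (0.39 log units; beyond the scatter), again beyond the scatter. Both steps give only a minimum size, as compound 4 stands at a limit and has no number: the limit of > 100000 nM in this assay, at which 2 of the 4 values shown sit.

From the compounds shown here alone, how far the loss runs past that limit stays open. So does whether an amine or a longer chain such as ethoxy on that oxygen would behave like methoxy or like hydroxy.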